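This account rests on a few compounds, and the source may have more. Where it says the series, first, only, none or still open, it means among the compounds named here.

In a functional assay on MDA-MB-231 cells (Homo sapiens) for antiproliferative activity, read by sulforhodamine B assay, with a stated time of 72 h (on this read-out lower numbers stand for stronger inhibition and higher numbers for weaker inhibition), compound 1 (`COc1ncc(-c2ccc3ncnc(NCCN(C)C)c3c2)cc1NS(C)(=O)=O`) gives 2320 nM and compound 2 (`CCCCS(=O)(=O)Nc1cc(-c2ccc3ncnc(NCc4ccncc4)c3c2)cnc1OC`) gives 4320 nM. These two numbers lie within the usual scatter of each other, so compound 1 stands level with compound 2 and the pair cannot be ranked.

Compound 3 (`COc1ncc(-c2ccc3ncnc(NCCN(C)C)c3c2)cc1NS(=O)(=O)c1ccc(F)cc1F`) keeps the rest of compound 1 and changes one group: 2,4-difluorophenyl in place of methyl on a sulfonyl sulfur. Put simply, 2,4-difluorophenyl sits in place of methyl on a sulfonyl sulfur, so a small group gives way to a much larger one that brings an aromatic ring.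

Among the measured compounds shown here, no two measured compounds here differ in only one place, so the data offer no earlier step to use as a guide. Any forecast is therefore a judgement and has to stay wide. The expected direction in this assay is toward stronger inhibition, with a moderate expected step of a 3.3-fold lower number from compound 1 to compound 3 (0.52 log units; beyond the scatter), and a result close to the starting number would not be surprising.

For compound 3 the estimated value is 700 nM, with an expected range from 120 nM to 3500 nM.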

Compound 3, half-maximal inhibitory concentration: 710 nM
The estimate for compound 3 lay 1.0-fold (0.01 log units) below the measured number; measured number inside the range.
By their numbers in this assay, from the lowest: compound 3; then compounds 1 and 2 (each within the scatter of the next).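

In this assay the group on the sulfonyl sulfur proves to matter: with the rest of compound 1 unchanged, 2,4-difluorophenyl in place of methyl gives a 3.3-fold lower number from compound 1 to compound 3 (0.51 log units; beyond the scatter) and this modest step lies beyond the scatter. Among the compounds shown here, this is the first comparison in the set in which only one place changes, so it is the first direct look at this position. It shows that a single carbon can give way to a much larger group with a six-membered aromatic ring, and that inhibition becomes stronger rather than being lost. No measurement shown here explains the shift, so it stands as an observation only.

A plain phenyl on the same sulfonyl sulfur would help to separate the contribution of the ring from that of its two fluorines. A longer chain such as n-propyl in that place would help to show whether a larger group without an aromatic ring gives a similar step.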